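The source may hold more compounds than are shown below. What is called first, only, known or untested is meant among the compounds shown, and "the series" means these compounds.

Measured so far:
- compound 1 `CCCC[C@@H]1O[C@H](COCc2ccccc2)[C@@H](OCc2ccccc2)[C@H](OCc2ccccc2)[C@H]1O`: "not active" (no number reported)
- compound 2 `ClC1(Cl)[C@@H]2[C@@H](OCc3ccccc3)[C@H](OCc3ccccc3)[C@@H](COCc3ccccc3)O[C@@H]21`: 46400 nM
- compound 3 `O[C@@H]1[C@@H](OCc2ccccc2)[C@H](OCc2ccccc2)[C@@H](COCc2ccccc2)O[C@@H]1Cc1ccccc1`: "not active" (no number reported)

In a functional assay on HL-60 cells (Homo sapiens) for antiproliferative activity, read by MTT assay (on this read-out higher numbers stand for weaker inhibition and lower numbers for stronger inhibition), compound 1 gives "not active" (no number reported), and no number stands against it. Compound 3 likewise gives "not active" (no number reported) in this assay. Only compound 2 carries a number, 46400 nM in this assay, and that number lies at the weak end of what this read-out reports. Compound 1 therefore stands without a value of its own, beside one further compound in the same position; where it falls relative to compound 2 cannot be read from the numbers shown.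

Compound 4 `CC[C@@H]1O[C@H](COCc2ccccc2)[C@@H](OCc2ccccc2)[C@H](OCc2ccccc2)[C@H]1O` differs from compound 1 in one place: hydrogen in place of ethyl on a saturated chain carbon, two bonds along the chain from a saturated ring carbon. Within the data shown here, no step between measured compounds touches this change, so no measured step can be borrowed for it. The expectation in this assay is for no step beyond the scatter, with compound 4 most likely reported as inactive, as compound 1 was. If a number is reported, compound 4 is expected near 90000 nM, in the range 30000 nM to 300000 nM.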

Compound 4, half-maximal inhibitory concentration: 8200 nM
Compound 4: middle estimate off by 11-fold (1.04 log units), on the high side; the whole stated range lies above it.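

Compound 1 carries no number in this assay and compound 4 gives 8200 nM, so no step can be read between them. The compounds shown leave open how activity on the shared core depends on chain length. No evidence bears on this result.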